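From a cyanophenyl amide to an ethylphenyl sulfonamide

The source may report more compounds than this note shows. Statements on the series, on what has been measured and on what is new or still open speak of the compounds shown alone.

Measured so far in an ADME assay on HepG2 2.2.15 cells (Homo sapiens) for cytotoxicity; a lower number here means that less compound is tolerated, a higher number that more compound is tolerated:
compound 1 `O=C(Nc1ncc(C(Oc2ccc3cc(Br)ccc3c2)c2ccc(Cl)cc2)s1)C1CC1`: "not toxic" (no number reported)
compound 2 `Cc1ccc(C(=O)Nc2ncc(C(Oc3ccc4cc(Br)ccc4c3)c3ccc(Cl)cc3)s2)cc1`: "not toxic" (no number reported)
compound 3 `N#Cc1cccc(C(=O)Nc2ncc(C(Oc3ccc4cc(Br)ccc4c3)c3ccc(Cl)cc3)s2)c1`: > 50000 nM, a limit of the assay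

The three compounds share one core and differ only in the group on the ring nitrogen. Compound 1 and compound 2 were reported as not toxic, without a number. For compound 3 the result is a limit of the assay rather than a number, namely > 50000 nM. Compound 3 therefore stands at the limit of > 50000 nM in this assay, at which 1 of the 3 values shown sits, and the other two entries carry no number at all.

Compound 4 `CCc1ccc(S(=O)(=O)Nc2ncc(C(Oc3ccc4cc(Br)ccc4c3)c3ccc(Cl)cc3)s2)cc1` is not yet measured. It differs from compound 3 by (4-ethylphenyl)sulfonyl in place of (3-cyanophenyl)carbonyl on a nitrogen on an aromatic ring. Among the compounds with values here, since no step between two numbered compounds exists here, the expected step is a number no higher from compound 3 to compound 4 (the limit leaves the size open), none beyond the scatter. Compound 4 is expected to give 50000 nM, within 20000 nM to 120000 nM, most likely again only as a limit.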

Compound 4, half-maximal cytotoxic concentration: > 50000 nM
Compound 4 was reported as a limit (the forecaster's own chance of this, stated with the estimate: 70%); the middle value lies on the limit itself.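

Within the data shown here, compound 3 and compound 4 are both reported only as a limit of the assay, and no step between them can be read. The compounds shown leave open at what concentration, if any, any of them harms the cells.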